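The source may report more compounds than this note shows. Statements on the series, on what has been measured and on what is new or still open speak of the compounds shown alone.

The measured compounds and their values in an ADME assay on cells (Epithelial cell, Homo sapiens) for antiproliferative activity, read by MTT assay, with a stated time of 48 h; a lower number here means a stronger inhibitor, a higher number a weaker inhibitor:

Compound 1 `COC(=O)/C(=C/c1ccccc1)CN1C(=O)[C@@H](OC)[C@H]1c1ccc(Cl)cc1` gives 37900 nM.
Compound 2 `COc1ccc(OC)c([C@@H]2[C@H](OC)C(=O)N2C/C(C#N)=C/c2ccccc2)c1` gives only a limit, > 100000 nM.
Compound 3 `CO[C@@H]1C(=O)N(C/C(C#N)=C/c2ccccc2)[C@@H]1c1ccc(Cl)cc1Cl` gives only a limit, > 100000 nM.

For the measured compounds named here, compound 1 therefore stands as the only compound of the three with a number in this assay. Compound 2 reports a limit rather than a number. Compound 3 also reports a limit rather than a number. Going by the values given here, both of those sit at the limit of > 100000 nM in this assay, at which 2 of the 3 values shown sit, so nothing can be said of how far apart the three compounds lie, and no step between measured compounds that differ in one place is available.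

Compound 4 `COC(=O)/C(=C/c1ccccc1)CN1C(=O)[C@@H](OC)[C@H]1c1ccccc1` is the compound to be measured. It differs from compound 1 by hydrogen in place of chloro on an aromatic carbon. Among the compounds with values here, with no measured step to lean on, the expectation rests on the size of such a change alone: a small step, more likely toward a weaker inhibitor than a stronger one, and quite possibly within the scatter of this assay. Compound 4 is thus expected to land at roughly 60000 nM, with a range from 20000 nM to 150000 nM. The step this estimate implies, a 1.6-fold higher number from compound 1 to compound 4 (0.20 log units; within the scatter), is expected to be modest, with a real chance that compound 4 reports only a limit.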

Compound 4, half-maximal inhibitory concentration: "not toxic" (no number reported)
No number was reported for compound 4; no gap can be computed for the estimate.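

In this assay compound 4 is recorded as "not toxic" (no number reported), and no step can be read between compound 1 and compound 4. The compounds shown leave open how far, if at all, the change from 4-chlorophenyl to phenyl moves the value in this assay.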